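Replacing Propylcarbonyl with Ethyl: What to Expect

The compounds below may be only part of what the source reports. "The series", "measured", "known", "first", "only" and "open" are said of these compounds alone.

Measured compounds:
compound 1, `CCCC(=O)c1c(C)nn(CCCN2CCN(c3ccc(C)cc3)CC2)c(=O)c1N`: 0%
compound 2, `C=Cc1c(CCC)nn(CCCN2CCN(c3ccc(C)cc3)CC2)c(=O)c1N`: 3%

Going by the values given here, both compounds share one core and have been tested in a functional assay on the whole organism (Abdomen, strain Swiss) for inhibition, with Mus musculus as the target, with stated times of 30 min, 10 min and 5 min, at a dose of 10 mg/kg by the oral route; a higher number here means a stronger effect of the compound at the dose given, a lower number a weaker effect. In this assay compound 1 gives 0%, and compound 2 gives 3%. Compound 1 stands as the lower of the two numbers, but the gap to compound 2 lies within the scatter of repeated measurements, so the two compounds cannot be told apart on these data; neither shows a clear effect at the dose given.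

Compound 3, `CCc1c(C)nn(CCCN2CCN(c3ccc(C)cc3)CC2)c(=O)c1N`, has not yet been measured. It differs from compound 1 in one place: ethyl in place of propylcarbonyl on an aromatic carbon. Among the compounds with values here, the pair compound 1 and compound 2 gives no usable step. Both sit near the bottom of the scale. Within the data shown here, there is thus no measured step to lean on. Given that compound 1 gives 0% in this assay, the expected step from compound 1 to compound 3 is a number 5 percentage points higher from compound 1 to compound 3 (within the scatter), that is, nothing beyond the scatter. Compound 3 is therefore estimated at 5%, with a range from 0% to 20%.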

Compound 3, a percentage reported as inhibition, in the whole organism at one dose (the size of the read-out at that dose, not a potency): 23%
Compound 3: middle estimate off by 18 percentage points, on the low side; the whole stated range lies below it.
By their numbers in this assay, from the lowest: compounds 1 and 2 (each within the scatter of the next); then compound 3.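

In this assay ethyl in place of propylcarbonyl on an aromatic carbon gives a number 23 percentage points higher from compound 1 to compound 3 (beyond the scatter) and so shows that this position, opposite the ring nitrogen, can change the effect seen at the dose given. Going by these compounds alone, the step is modest, but it is the first single change here to stand clear of the scatter, so the position is not indifferent to what is placed on it. The group that leaves has 5 heavy atoms and a hydrogen-bond acceptor, the group that enters has 2 heavy atoms and no acceptor, and nothing measured here says which of these differences matters or what lies behind the step.

Within the data shown here, the single pair leaves open whether the carbonyl or the length of the chain is what counts: acetyl would keep the carbonyl on a shorter chain, while propyl would remove it and keep a longer chain. Methyl or hydrogen at the same place would also show whether still smaller groups carry the effect further, and a read-out at a single dose cannot say how the compounds compare at other doses.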